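Coumarin-lipoic acid triazole series: cytotoxicity on PC-12 cells

The source may report more compounds than this note shows. Statements on the series, on what has been measured and on what is new or still open speak of the compounds shown alone.

Three compounds share one core and differ only in the aryl group on the aromatic carbon two atoms from the ring oxygen. Compound 1 `O=C(CCCCC1CCSS1)NCc1cn(CCCCCOc2ccc3cc(-c4ccccc4)c(=O)oc3c2)nn1` carries phenyl there; in a functional assay on PC-12 cells (Rattus norvegicus) for cytotoxicity, read by MTT assay, with stated times of 3 h and 2 h, tested at 20 uM (on this read-out lower numbers stand for a weaker effect and higher numbers for a stronger effect at the one concentration tested), compound 1 gives 20.7%. Compound 2 `COc1ccc(-c2cc3ccc(OCCCCCn4cc(CNC(=O)CCCCC5CCSS5)nn4)cc3oc2=O)cc1OC` carries 3,4-dimethoxyphenyl and gives 51.9% in this assay. Compound 3 `O=C(CCCCC1CCSS1)NCc1cn(CCCCCOc2ccc3cc(-c4ccc(Br)cc4)c(=O)oc3c2)nn1` carries 4-bromophenyl and gives 52.3% in this assay, the highest of the three numbers, though its gap to compound 2 is within the scatter: a number 0.4 percentage points higher from compound 2 to compound 3 (within the scatter). Both substituted aryls sit well apart from phenyl: a number 31.2 percentage points higher from compound 1 to compound 2 (beyond the scatter) and a number 31.6 percentage points higher from compound 1 to compound 3 (beyond the scatter).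

Compound 4 `O=C(CCCCC1CCSS1)NCc1cn(CCCCCOc2ccc3cc(-c4ccc(Cl)c(Cl)c4)c(=O)oc3c2)nn1` is not yet measured. Relative to compound 3 the change is 3,4-dichlorophenyl in place of 4-bromophenyl on an aromatic carbon. Both steps that bear on it, from compound 1 to compound 2 and from compound 1 to compound 3, show that any substituted phenyl at this position lands close to the same level, and the step from compound 2 to compound 3 shows no difference between two such aryls. Compound 4 is therefore expected to stay with compounds 2 and 3, with no step beyond the scatter: a number 1.3 percentage points lower from compound 3 to compound 4 (within the scatter). The estimate for compound 4 in this assay is 51%, within 36% to 66%.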

Compound 4, a percentage reported as activity, at one concentration (the size of the read-out at that concentration, not a potency): 65.5%
For compound 4 the middle estimate is 14.5 percentage points below the measured one, and the stated range covers the measured number.
By their numbers in this assay, from the lowest: compound 1; then compounds 2 and 3 (each within the scatter of the next); then compound 4.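

In this assay the level shared by compounds 2 and 3 is not a ceiling for substituted aryls at this position: 3,4-dichlorophenyl gives a number 13.2 percentage points higher from compound 3 to compound 4 (beyond the scatter) and a number 13.6 percentage points higher from compound 2 to compound 4 (beyond the scatter) and also stands well clear of plain phenyl with a number 44.8 percentage points higher from compound 1 to compound 4 (beyond the scatter) as the widest step in the series. The change from 4-bromophenyl swaps the halogen and adds a second substituent on the aryl ring in one step, and these two changes cannot be separated here. No measurement at hand accounts for the step.

Open, as far as these compounds go, is whether the gain follows the chlorine or the second halogen, which 4-chlorophenyl and 3,4-dibromophenyl would separate. Also open, from the compounds shown here alone, is how an aryl bearing an amine or a carboxylic acid would stand in this assay against these halogenated ones.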